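Swapping an aryl ring for a chlorophenylpropyl chain

This account rests on a few compounds, and the source may have more. Where it says the series, first, only, none or still open, it means among the compounds named here.

Of the compounds shown here, two of a shared core have been measured in a functional assay on CHO cells with adenosine receptor A1 (Homo sapiens) as the target, read by cAMP accumulation and immunoassay, with a stated time of 6 min, tested at 0.1 uM; on this read-out higher numbers stand for a weaker effect at the one concentration tested and lower numbers for a stronger effect. Compound 1 `Nc1scc(CN2CCN(c3ccccc3C(F)(F)F)CC2)c1C(=O)c1ccc(Cl)cc1` gives -7.5%. Compound 2 `Nc1scc(CN2CCN(c3c(F)cccc3F)CC2)c1C(=O)c1ccc(Cl)cc1` gives -23%, the lowest of the two numbers, the only other one being that of compound 1. For the measured compounds named here, the one measured step, a number 15.5 percentage points lower from compound 1 to compound 2 (beyond the scatter), was 2,6-difluorophenyl in place of 2-(trifluoromethyl)phenyl on an amine nitrogen in a ring.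

Compound 3 `Nc1scc(CN2CCN(CCCc3ccc(Cl)cc3)CC2)c1C(=O)c1ccc(Cl)cc1` is not yet measured. It differs from compound 2 as follows: 3-(4-chlorophenyl)propyl in place of 2,6-difluorophenyl on an amine nitrogen in a ring. Going by the values given here, no measured step exchanges a ring for a chain at that nitrogen, so the step from the first pair offers only loose guidance about how much the number may move. A step of modest size in either direction, or none beyond the scatter, is expected, a number 13 percentage points higher from compound 2 to compound 3 (beyond the scatter). Compound 3 is therefore estimated at -10%, within a range from -40% to 20%.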

Compound 3, a percentage reported as activity, at one concentration (the size of the read-out at that concentration, not a potency): -3%
The estimate for compound 3 lay 7 percentage points below the measured number, within the range that was stated.
By their numbers in this assay, from the lowest: compound 2; then compounds 1 and 3 (each within the scatter of the next).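

At this amine nitrogen, a ring bonded directly to the nitrogen is not needed to give a number like that of compound 1 in this assay: 3-(4-chlorophenyl)propyl in place of 2-(trifluoromethyl)phenyl gives no clear change (a number 4.5 percentage points higher from compound 1 to compound 3 (within the scatter)). The same chain does not keep the lower number seen with 2,6-difluorophenyl (a number 20 percentage points higher from compound 2 to compound 3 (beyond the scatter)), so compound 2 remains the only one of the three that stands apart, with the stronger effect on this read-out. Nothing shown explains why the numbers move this way.

Going by these compounds, whether the length of the chain or its chlorine matters remains open, and a shorter chain, a longer chain or a chain ending in unsubstituted phenyl could separate the two. A single tested concentration also leaves the potencies of all three compounds unknown.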